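A few compounds are considered here, and "the series" means these few. Any claim that something is new, unique, unknown or untested is made for them only; others in the source may bear on it.

Compound 2 `CC(C)(C)c1cc(NC(=O)Nc2ccc(Nc3ncnc4c3OCCN4)cc2)no1` is the stronger of the two measured ureas in an assay on isolated protein for inhibition of proto-oncogene tyrosine-protein kinase receptor Ret (Homo sapiens), read by 33P incorporation, with stated times of 15 min and 40 min; a lower number here means a stronger inhibitor, a higher number a weaker inhibitor. Going by the values given here, compound 2 gives 10 nM, the lower of the two numbers so far, while compound 1 `Cc1ccc(F)c(NC(=O)Nc2ccc(Nc3ncnc4c3OCCN4)cc2)c1` gives 1470 nM in this assay. Among the compounds with values here, the single measured step, a 150-fold lower number from compound 1 to compound 2 (2.17 log units; beyond the scatter), concerns the aryl group on the amide-type nitrogen and is large. Compound 3 `COc1cc(NC(=O)Nc2cc(C(C)(C)C)on2)ccc1Nc1ncnc2c1OCCN2` keeps the 5-(tert-butyl)-1,2-oxazol-3-yl urea of compound 2 and differs only in methoxy in place of hydrogen on an aromatic carbon. Within the data shown here, no measured step touches this ring of the shared core, so the step from compound 1 to compound 2 does not bear on it directly, and nothing in the numbers points to a change beyond the scatter. Compound 3 is therefore expected to show no change at the digits printed from compound 2 to compound 3 (within the scatter) in this assay, that is, an estimated 10 nM with a range of 3 nM to 30 nM.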

Compound 3, half-maximal inhibitory concentration: 22 nM
Beside the measured number, compound 3's estimate is 2.2-fold (0.34 log units) below it, and the stated range covers the measured number.
By their numbers in this assay, from the lowest: compound 2; then compound 3; then compound 1.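

Going by these compounds alone, the methoxy on this aromatic carbon, ortho to a large group and meta to a large group, gives the first reading at this place on the shared core: in this assay there is a 2.2-fold higher number from compound 2 to compound 3 (0.34 log units; beyond the scatter), a modest step just beyond the scatter. This step is far smaller than a 150-fold lower number from compound 1 to compound 2 (2.17 log units; beyond the scatter), which came from the group on the amide-type nitrogen, and compound 3 keeps a low number at 22 nM. No supporting measurement accounts for the rise in the number.

Going by these compounds, what an ethoxy, a chlorine atom or an amine on this carbon would give remains open. Also open, on these data alone, is whether methoxy would shift the number similarly with the 2-fluoro-5-methylphenyl urea of compound 1.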